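The source may report more compounds than this note shows. Statements on the series, on what has been measured and on what is new or still open speak of the compounds shown alone.

Among the compounds with values here, compound 3 `C=CC(=O)Nc1cc(Nc2ncc(Cl)c(N3CCc4sccc4C3)n2)c(OC)cc1N(C)CCN(C)C` sits at the lowest number among the three measured members. In a functional assay on NCI-H1975 cells (Homo sapiens) for cytotoxicity, read by MTT assay (on this read-out lower numbers stand for stronger inhibition and higher numbers for weaker inhibition), compound 3 gives 242 nM. Compound 1 `COc1cc(N(C)CCN(C)C)c(NC(=O)/C=C/C(C)C)cc1Nc1ncc(Cl)c(N2CCc3sccc3C2)n1`, which carries 3-methylbut-1-en-1-yl on the carbonyl carbon, gives 472 nM in this assay; the step of a 2.0-fold lower number from compound 1 to compound 3 (0.29 log units; within the scatter) is the closest comparison to compound 3. Compound 2 `C=CC(=O)Nc1ccc(OC)c(Nc2ncc(Cl)c(N3CCc4sccc4C3)n2)c1`, lacking the (2-(dimethylamino)ethyl)(methyl)amino group, gives 786 nM in this assay, and the step of a 3.2-fold lower number from compound 2 to compound 3 (0.51 log units; beyond the scatter) separates it from compound 3.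

Compound 4 `COc1cc(N(C)CCN(C)C)c(NC(=O)C=C(C)C)cc1Nc1ncc(Cl)c(N2CCc3sccc3C2)n1` is not yet measured. It differs from compound 3 at the carbonyl carbon: 2-methylprop-1-en-1-yl in place of vinyl on a carbonyl carbon. Within the data shown here, the only measured step that touches the same position is the one from compound 1 to compound 3, where a branched alkenyl gave way to vinyl and the number fell, though within the scatter. The change to compound 4 runs the other way, putting a branched alkenyl back in place of vinyl, so a step of similar or somewhat larger size toward a higher number is expected, with a 3.7-fold higher number from compound 3 to compound 4 (0.57 log units; beyond the scatter) as the estimated move. Compound 4 is therefore expected to give about 900 nM in this assay, within a range from 350 nM to 2500 nM.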

Compound 4, half-maximal inhibitory concentration: 280 nM
Beside the measured number, compound 4's estimate is 3.2-fold (0.51 log units) above it, outside the stated range (below it).
By their numbers in this assay, from the lowest: compounds 3, 4, 1 and 2 (each within the scatter of the next, the first and the last beyond it).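

In this assay, the carbonyl carbon now has three measured groups, vinyl, 2-methylprop-1-en-1-yl and 3-methylbut-1-en-1-yl, and neither a 1.2-fold higher number from compound 3 to compound 4 (0.06 log units; within the scatter) nor a 1.7-fold lower number from compound 1 to compound 4 (0.23 log units; within the scatter) leaves the scatter, so together with the earlier step between compound 1 and compound 3 these numbers do not tell the three groups apart. With 2-methylprop-1-en-1-yl, 4 carbon atoms enter where vinyl has 2, and the number does not separate from that of compound 3, so among these compounds the only step beyond the scatter remains a 3.2-fold lower number from compound 2 to compound 3 (0.51 log units; beyond the scatter), a change on an aromatic carbon and not at the carbonyl carbon. Nothing available bears on why the three groups read alike in this assay.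

Still open, from the compounds shown here alone, is whether this reading holds at the same carbonyl carbon for a group without a double bond, such as ethyl, or for an alkenyl chain carrying a dimethylamino group. Also open, going by these compounds, is whether removing the (2-(dimethylamino)ethyl)(methyl)amino group from compound 4 or compound 1 would give a step of the size seen with vinyl.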